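Amino to carboxy on a weakly active series

The compounds below may be only part of what the source reports. "The series", "measured", "known", "first", "only" and "open" are said of these compounds alone.

Compound 1 `N#Cc1ccc(Nc2nc(NC3CCCC3)c3ccccc3n2)cc1`: > 31300 nM (a limit of the assay)
Compound 2 `Nc1ccc(Nc2nc(NC3CCCC3)c3ccccc3n2)cc1`: 21700 nM

Among the compounds with values here, in a functional assay on KBVIN cells (Homo sapiens) for antiproliferative activity, read by sulforhodamine B assay, with a stated time of 48 h (a higher number here means a weaker inhibitor of growth, a lower number a stronger inhibitor of growth), compound 2 gives 21700 nM, the only number available so far. Compound 1 gives > 31300 nM, which is a limit and not a number.

Compound 3 `O=C(O)c1ccc(Nc2nc(NC3CCCC3)c3ccccc3n2)cc1` departs from compound 2 in one place, with carboxy in place of amino on an aromatic carbon, para to a large group: carboxy in place of amino on an aromatic carbon.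

Within the data shown here, only one measured step bears on this place: an at least 1.4-fold lower number from compound 1 to compound 2 (0.15 log units; that floor lies within the scatter), with amino in place of cyano. Its floor lies within the scatter, and it rests on (the limit of > 31300 nM in this assay, at which 1 of the 2 values shown sits), so it gives no firm size and only a lower bound. Among the measured compounds shown here, no large step is therefore expected in this assay. A small move toward a higher number, meaning weaker inhibition of growth, seems the likelier outcome, and the assay may report only a limit. The expected step is a 1.4-fold higher number from compound 2 to compound 3 (0.14 log units; within the scatter). For compound 3 the estimated value is 30000 nM, with an expected range from 13000 nM to 70000 nM.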

Compound 3, concentration for 50% growth inhibition in the KBVIN assay: 19800 nM
For compound 3 the middle estimate is 1.5-fold (0.18 log units) above the measured one, and the stated range covers the measured number.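

In the KBVIN assay compound 3, with carboxy in place of amino on an aromatic carbon, para to a large group, gives 19800 nM and the step is a 1.1-fold lower number from compound 2 to compound 3 (0.04 log units; within the scatter), which lies within the scatter. Within the data shown here, with this result, the position carries two groups with actual numbers, amino and carboxy, and these cannot be told apart, whereas the earlier compounds offered only one number and one limit. The comparison of carboxy with cyano at the same place gives an at least 1.5-fold lower number from compound 1 to compound 3 (0.19 log units; that floor lies within the scatter), and this floor also lies within the scatter, so it yields a lower bound and no firm size, resting as it does on a limit of the assay: the limit of > 31300 nM in the KBVIN assay, at which 1 of the 3 values shown sits.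

Still open, on these data alone, is whether any group on this aromatic carbon can move the number beyond the scatter, a question that a methoxy group, a methyl ester, a primary amide or a longer chain ending in a carboxylic acid could each address. In a physicochemical assay for lipophilicity, read by HPLC, measured as octanol-water partition, with a stated time of 24 h (on this read-out higher numbers stand for higher lipophilicity and lower numbers for lower lipophilicity), compound 2 gives "not determined" (no result reported) and compound 3 gives "not determined" (no result reported) so no step can be read for this pair, and the shown results do not relate growth inhibition to this read-out.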